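Aryl variation on the ring amine of the aminothiophene series

The source may report more compounds than this note shows. Statements on the series, on what has been measured and on what is new or still open speak of the compounds shown alone.

Compound 2 `Nc1scc(CN2CCN(c3ccc([N+](=O)[O-])cc3)CC2)c1C(=O)c1ccc(Cl)cc1` gives -13% in a functional assay on CHO cells with adenosine receptor A1 (Homo sapiens) as the target, read by cAMP accumulation and immunoassay, with a stated time of 6 min, tested at 0.1 uM; on this read-out higher numbers stand for a weaker effect at the one concentration tested and lower numbers for a stronger effect. For the measured compounds named here, on the numbers so far it stands level with compound 3 `Nc1scc(CN2CCN(c3cc(F)ccc3F)CC2)c1C(=O)c1ccc(Cl)cc1`, which gives -13%; together the two are the lowest of the three values. The furthest is compound 1 `CC(C)N1CCN(Cc2csc(N)c2C(=O)c2ccc(Cl)cc2)CC1`, at 3.6%; the step that separates them is a number 16.6 percentage points lower from compound 1 to compound 2 (beyond the scatter).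

Compound 4 `Nc1scc(CN2CCN(c3cc(Cl)ccc3Cl)CC2)c1C(=O)c1ccc(Cl)cc1` is the next member. It differs from compound 2 by 2,5-dichlorophenyl in place of 4-nitrophenyl on an amine nitrogen in a ring.

Bearing on this change: the step of no change at the digits printed from compound 2 to compound 3 (within the scatter) swaps one aryl group on the ring amine for another and shows nothing beyond the scatter. The steps of a number 16.6 percentage points lower from compound 1 to compound 2 (beyond the scatter) and a number 16.6 percentage points lower from compound 1 to compound 3 (beyond the scatter) concern isopropyl against an aryl group and are only indirect. For compound 4 the expectation is therefore a number 1 percentage points higher from compound 2 to compound 4 (within the scatter), no move beyond the scatter. Compound 4 is estimated at -12%, with a range from -30% to 8%.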

Compound 4, a percentage reported as activity, at one concentration (the size of the read-out at that concentration, not a potency): -6.2%
Beside the measured number, compound 4's estimate is 5.8 percentage points below it, and the stated range covers the measured number.
By their numbers in this assay, from the lowest: compounds 2, 3, 4 and 1 (each within the scatter of the next, the first and the last beyond it).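

With 2,5-dichlorophenyl on the ring amine, this assay shows a number 6.8 percentage points higher from compound 2 to compound 4 (within the scatter) and a number 6.8 percentage points higher from compound 3 to compound 4 (within the scatter), so three aryl groups on this amine nitrogen now stand within the scatter of one another. The tolerance seen between 4-nitrophenyl and 2,5-difluorophenyl therefore extends to 2,5-dichlorophenyl. The contrast with isopropyl is less clean: the reading is a number 9.8 percentage points lower from compound 1 to compound 4 (within the scatter), whereas compound 2 and compound 3 each lie beyond the scatter from compound 1, so compound 4 goes against any rule that an aryl group on this nitrogen separates the series from isopropyl.

Nothing available here gives a reason for these readings. Still open, going by these compounds, is how an unsubstituted phenyl, a benzyl group, a carboxylic acid on the aryl ring or a longer alkyl chain on this nitrogen would read.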